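Chain-terminal cation and aryl substituent in quinolone carboxamides

The compounds below may be only part of what the source reports. "The series", "measured", "known", "first", "only" and "open" are said of these compounds alone.

Measured compounds:
compound 1 `Cc1ccc(-n2cc(C(=O)Nc3cc(F)cc(F)c3)c(=O)c3ccc(N(C)C)nc32)cc1OCCCCCCC[N+]12CCN(CC1)CC2` — 9.71%
compound 2 `CN(C)c1ccc2c(=O)c(C(=O)Nc3cc(F)cc(F)c3)cn(-c3ccc(Cl)c(OCCCCCCC[N+]45CCN(CC4)CC5)c3)c2n1` — 18.7%
compound 3 `Cc1cc(OCCCCCCC[n+]2ccccc2)ccc1-n1cc(C(=O)Nc2cc(F)cc(F)c2)c(=O)c2ccc(N(C)C)nc21` — "not active" (no number reported)

All three were run in an assay on LX2 cells for inhibition of COL1A1 promoter (Homo sapiens), read by a luciferase reporter, with a stated time of 24 h, tested at 50 uM; a higher number here means a stronger effect of the compound at the concentration tested, a lower number a weaker effect. Compound 1 gives 9.71% and compound 2 gives 18.7%. The pair differs by chloro in place of methyl on an aromatic carbon and the resulting step is a number 9 percentage points higher from compound 1 to compound 2 (within the scatter), so the two values cannot be told apart. Compound 3 is reported as "not active" (no number reported); no single number is given for it. The difference between the core of compound 1 and the core of compound 3 is not broken down here.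

Compound 4 `CN(C)c1ccc2c(=O)c(C(=O)Nc3cc(F)cc(F)c3)cn(-c3ccc(OCCCCCCC[n+]4ccccc4)cc3Cl)c2n1` is not yet measured. It arises from compound 3 by chloro in place of methyl on an aromatic carbon. Within the data shown here, this is the same kind of change as the one from compound 1 to compound 2, though the surroundings differ: in the first pair the position is para to a large group, in the second it is meta to a large group.

Given that the earlier step was a number 9 percentage points higher from compound 1 to compound 2 (within the scatter) and that compound 3 shows "not active" (no number reported), compound 4 is expected to remain weak, with a fair chance that it too is reported without a number. The estimate for compound 4 in this assay is 8%, with a range of 0% to 25%, resting on the small step seen from compound 1 to compound 2 and the inactivity of compound 3.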

Compound 4, a percentage reported as inhibition, at one concentration (the size of the read-out at that concentration, not a potency): "not active" (no number reported)
No number was reported for compound 4; the estimate stays without a comparison.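

In this assay compound 3 gives "not active" (no number reported) and compound 4 gives "not active" (no number reported), so no step can be read for chloro in place of methyl within this pair. No evidence on this result is available. The compounds shown leave open whether this exchange has any measurable effect on the read-out when the chain ends in the cation of compound 3.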